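Replacing 2-chlorophenyl with 3-methylphenyl in compound 3

This account rests on a few compounds, and the source may have more. Where it says the series, first, only, none or still open, it means among the compounds named here.

compound 1 `NC(=O)c1cc(Cl)ccc1NC(=O)/C=C/c1ccccc1Br`: 10000 nM
compound 2 `Cc1ccc(/C=C/C(=O)Nc2ccc(Cl)cc2C(N)=O)cc1`: 6300 nM
compound 3 `NC(=O)c1cc(Br)ccc1NC(=O)/C=C/c1ccccc1Cl`: 8100 nM

These three compounds were measured in a functional assay on K562 cells (Homo sapiens) for inhibition, read by trypan blue exclusion, with a stated time of 48 h (a lower number here means a stronger inhibitor, a higher number a weaker inhibitor), and lie close together. Compound 3 (8100 nM) falls within the scatter of both compound 1 and compound 2, so no order can be read among the three.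

Compound 4 `Cc1cccc(/C=C/C(=O)Nc2ccc(Br)cc2C(N)=O)c1` has not yet been measured. It differs from compound 3 by having 3-methylphenyl in place of 2-chlorophenyl on a double-bonded chain carbon bound to a double-bonded chain carbon.

Within the data shown here, only one measured step bears on this change. At the same place, 4-methylphenyl in place of 2-bromophenyl gave a 1.6-fold lower number from compound 1 to compound 2 (0.20 log units; within the scatter) in this assay. Among the measured compounds shown here, no measured compound carries 3-methylphenyl, so that step is only a rough guide. On this evidence, no step beyond the scatter is expected, and the estimated result is a 1.2-fold lower number from compound 3 to compound 4 (0.06 log units; within the scatter). For compound 4 the estimated value is 7000 nM, with an expected range from 3500 nM to 14000 nM.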

Compound 4, half-maximal inhibitory concentration: > 10000 nM
Compound 4: no number, only a limit; the forecaster's own chance of this, stated with the estimate: 8%; at least 1.4-fold (0.15 log units) between middle value and limit.
By their numbers in this assay, from the lowest: compounds 2, 3 and 1 (each within the scatter of the next).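

In this assay compound 4 gives > 10000 nM, which is a limit of the assay and not a number, and it is the only one of the compounds shown whose reading stops at a limit: the limit of > 10000 nM in this assay, at which 1 of the 4 values shown sits.

Going by these compounds, at this place, on a double-bonded chain carbon bound to a double-bonded chain carbon, the change from 2-chlorophenyl to 3-methylphenyl can be read only as a floor, an at least 1.2-fold higher number from compound 3 to compound 4 (0.09 log units; that floor lies within the scatter), so its true size stays unknown and it cannot be called a loss beyond the scatter. The earlier step, a 1.6-fold lower number from compound 1 to compound 2 (0.20 log units; within the scatter), had a number on both sides and also stayed within the scatter, whereas this change to a methyl-bearing phenyl shows no lowering of the number from the 2-chlorophenyl compound.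

On these data alone, it remains open what number compound 4 would give if read in full, and whether 3-methylphenyl and 4-methylphenyl differ at this place on an otherwise identical core. Also open, as far as these compounds go, is how a phenyl ring carrying an amine or a carboxylic acid would read here in this assay.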